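The source may hold more compounds than are shown below. What is called first, only, known or untested is meant among the compounds shown, and "the series" means these compounds.

Measured in an ADME assay on HCT-116 cells (Homo sapiens) for cytotoxicity, read by CellTiter-Glo, with a stated time of 72 h (a higher number here means a weaker inhibitor, a lower number a stronger inhibitor), as follows:
Compound 1 `Cc1cc(C)c(S(=O)(=O)N2CCN(C3CN4CCC3CC4)CC2)c(C)c1` reads > 5000 nM as a limit.
Compound 2 `Cc1cc(C)c(S(=O)(=O)N2CCC(N3CCC(CCO)CC3)CC2)c(C)c1` reads > 5000 nM as a limit.
Compound 3 `CC1CCN(C2CCN(S(=O)(=O)c3ccc(-c4ccccc4F)cc3)CC2)CC1` reads > 5000 nM as a limit.

Compound 3 stands with compound 1 and compound 2 at the limit of > 5000 nM in this assay, at which 3 of the 3 values shown sit, and has no number of its own. Compound 4 `CC1CCN(C2CCN(S(=O)(=O)c3ccc(-c4ccc(Cl)cc4)cc3)CC2)CC1` carries 4-chlorophenyl in place of 2-fluorophenyl on an aromatic carbon, para to a large group 4-chlorophenyl in place of 2-fluorophenyl on an aromatic carbon and is not yet measured.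

Among the compounds with values here, no step between measured compounds is available, so the series gives no size for such a change in this assay and the expectation rests only on the shared limit. The expected step is none beyond the scatter, with a modest shift toward stronger inhibition as the only other outcome allowed for. The estimated change, a number no higher from compound 3 to compound 4 (the limit leaves the size open) is therefore small. For compound 4 the expected value is 5000 nM with an estimated range from 1500 nM to 10000 nM and a reading at the limit remains the likeliest result.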

Compound 4, half-maximal inhibitory concentration: > 5000 nM
Compound 4: no number, only a limit; the forecaster's own chance of this, stated with the estimate: 65%; the middle value sits exactly at the limit.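

Compound 3 and compound 4 both sit at a limit rather than a number in this assay, so no step can be read between them: the limit of > 5000 nM in this assay, at which 4 of the 4 values shown sit.

The compounds shown leave open whether 4-chlorophenyl and 2-fluorophenyl differ at all in this assay, and what number any of these compounds would give.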